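Fluoro in place of trifluoromethoxy: notes on two analogues

The source may report more compounds than this note shows. Statements on the series, on what has been measured and on what is new or still open speak of the compounds shown alone.

Of the compounds shown here, two have been measured in a functional assay on HCT-116 cells (Homo sapiens) for inhibition, read by sulforhodamine B assay, with a stated time of 72 h; on this read-out lower numbers stand for stronger inhibition and higher numbers for weaker inhibition. Compound 1 `CC(c1ccc(-c2ccccc2)c(F)c1)c1nnc2n1N=C(c1ccc(Cl)cc1Cl)CS2` gives 6900 nM in this assay. Compound 2 `CC(C)Cc1ccc(C(C)c2nnc3n2N=C(c2ccc(OC(F)(F)F)cc2)CS3)cc1` gives 3000 nM in this assay, the lowest of the two numbers; the gap from compound 1 lies beyond the usual scatter, so compound 2 stands as the stronger inhibitor of the pair. The two compounds differ in more than one place, so no single step can be read from them.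

Compound 3 `CC(C)Cc1ccc(C(C)c2nnc3n2N=C(c2ccc(F)cc2)CS3)cc1` is the next analogue, not yet measured. Relative to compound 2 the change is fluoro in place of trifluoromethoxy on an aromatic carbon, on an aromatic carbon of a six-membered aromatic ring of carbon only, para to a large group. The shared core and the isobutyl-bearing ring are kept as in compound 2.

Within the data shown here, no measured pair shows this change, so its size is open. The step from compound 2 to compound 3 is expected to be small, a 1.5-fold higher number from compound 2 to compound 3 (0.18 log units; within the scatter), at or near the scatter, with a modest rise in the number the more likely direction. Compound 3 is therefore estimated at 4500 nM in this assay, within a range from 1500 nM to 14000 nM.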

Compound 3, half-maximal inhibitory concentration: 12400 nM
The estimate for compound 3 lay 2.8-fold (0.44 log units) below the measured number; the range from low to high includes it.
By their numbers in this assay, from the lowest: compound 2; then compounds 1 and 3 (each within the scatter of the next).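

Notes on the trifluoromethoxy position

In this assay, replacing trifluoromethoxy with fluoro on this aromatic carbon, para to a large group, gives a 4.1-fold higher number from compound 2 to compound 3 (0.62 log units; beyond the scatter), so this position is not indifferent to the change and the two groups cannot be treated as interchangeable here. Among these compounds, with the shared core and the isobutyl-bearing ring held as in compound 2, this is the only single-place step available so far, and it leaves compound 2 with the lowest number, while steps involving compound 1 cannot be read because it differs from the others in more than one place. No measured property of these compounds bears on the rise in the number.

Going by these compounds, two groups on one aromatic carbon do not define a trend, so it remains open whether a methoxy group, a nitrile or an amine at this position would give a number close to that of compound 2 or close to that of compound 3. On these data alone, it is also open whether the step keeps its size when a carboxylic acid or a longer chain stands in place of the isobutyl group.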